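The source may report more compounds than this note shows. Statements on the series, on what has been measured and on what is new or still open speak of the compounds shown alone.

Measured in a functional assay on HepG2 cells (Homo sapiens) for cytotoxicity, read by MTT assay, with a stated time of 24 h; on this read-out lower numbers stand for stronger inhibition and higher numbers for weaker inhibition:
- compound 1 `O=C1/C(=C/c2ccccc2F)CN(S(=O)(=O)c2ccc(F)cc2)C/C1=C\c1ccccc1F` gives 7220 nM
- compound 2 `O=C1/C(=C/c2cccc([N+](=O)[O-])c2)CN(S(=O)(=O)c2ccc(F)cc2)C/C1=C\c1ccccc1F` gives 7040 nM
- compound 3 `COc1cc(/C=C2\CN(S(=O)(=O)c3ccc(F)cc3)C/C(=C\c3ccccc3F)C2=O)cc(OC)c1OC` gives 7940 nM

Compound 3 stands within the scatter of both other measured compounds, as shown by a 1.1-fold higher number from compound 1 to compound 3 (0.04 log units; within the scatter) and a 1.1-fold higher number from compound 2 to compound 3 (0.05 log units; within the scatter). Compound 4 `COc1cc(/C=C2\CN(S(=O)(=O)c3ccc(F)cc3)C/C(=C\c3cc(OC)c(OC)c(OC)c3)C2=O)cc(OC)c1` differs from compound 3 as follows: 3,5-dimethoxyphenyl in place of 2-fluorophenyl on a double-bonded chain carbon bound to a double-bonded ring carbon. The measured steps that bear on this change are those two and a 1.0-fold lower number from compound 1 to compound 2 (0.01 log units; within the scatter). Each exchanges one substituted phenyl group for another at the same kind of place, and none leaves the scatter. All three measured compounds still carry a 2-fluorophenyl, so no measurement shows what happens once none remains, and the expectation is correspondingly uncertain. On the measured steps alone, no change beyond the scatter is expected in this assay. The expected step is a 1.1-fold lower number from compound 3 to compound 4 (0.02 log units; within the scatter). Compound 4 is estimated at 7500 nM, with an expected range from 4000 nM to 14000 nM.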

Compound 4, half-maximal inhibitory concentration: 3890 nM
Beside the measured number, compound 4's estimate is 1.9-fold (0.29 log units) above it; measured number below the stated range.
By their numbers in this assay, from the lowest: compounds 4, 2, 1 and 3 (each within the scatter of the next, the first and the last beyond it).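

In this assay, replacing the remaining 2-fluorophenyl gives a 2.0-fold lower number from compound 3 to compound 4 (0.31 log units; beyond the scatter), a modest change and the only step among these compounds that lies beyond the scatter. The earlier exchanges of one substituted phenyl group for another all left a 2-fluorophenyl in the molecule and stayed within the scatter, so compound 4 gives the first sign that the series responds to a change on a double-bonded chain carbon bound to a double-bonded ring carbon once no 2-fluorophenyl remains. Nothing available explains this step.

From the compounds shown here alone, with a single step, it remains open whether the shift follows from losing the 2-fluorophenyl or from gaining the 3,5-dimethoxyphenyl. Also open, going by these compounds, is how an amine or a carboxylic acid would behave at this place in this assay.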